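Carbamoylmethyl on the ring nitrogen of compound 3

The compounds below may be only part of what the source reports. "The series", "measured", "known", "first", "only" and "open" are said of these compounds alone.

Three sulfonamides of one dichlorophenyl sulfonyl group have numbers in a functional assay on CHO cells for antagonist activity at C-C chemokine receptor type 4 (Homo sapiens), read by radioligand binding and GTPgammaS binding; a lower number here means a stronger inhibitor, a higher number a weaker inhibitor. Compound 1 `COc1cccc2c1c(NS(=O)(=O)c1cccc(Cl)c1Cl)nn2C` gives 603 nM in this assay. Compound 2 `COc1cc2[nH]c(=O)[nH]c2cc1NS(=O)(=O)c1cccc(Cl)c1Cl` gives 316 nM. Compound 3 `COc1cc2c(cc1NS(=O)(=O)c1cccc(Cl)c1Cl)[nH]c(=O)n2C` gives 200 nM, the lowest of the three numbers; its gap to compound 2 stays within the scatter, while its gap to compound 1 lies beyond it. Among the measured compounds shown here, the only single-point step inside the set is a 1.6-fold lower number from compound 2 to compound 3 (0.20 log units; within the scatter), which does not rise above the scatter.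

Compound 4 `COc1cc2c(cc1NS(=O)(=O)c1cccc(Cl)c1Cl)[nH]c(=O)n2CC(N)=O` is not yet measured in this assay. Relative to compound 3 the change is carbamoyl in place of hydrogen on a saturated chain carbon bound to an aromatic nitrogen. For the measured compounds named here, no measured pair carries this kind of change; the nearest precedent is the step at the same aromatic nitrogen, a 1.6-fold lower number from compound 2 to compound 3 (0.20 log units; within the scatter), and that step was small. The new group brings one hydrogen-bond donor and one acceptor where compound 3 has none on that chain, so the direction is open in either sense. On the evidence at hand the expected step of a 1.3-fold higher number from compound 3 to compound 4 (0.10 log units; within the scatter) is none beyond the scatter, and compound 4 is therefore estimated at 250 nM, with a range from 90 nM to 700 nM.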

Compound 4, half-maximal inhibitory concentration: 457 nM
Compound 4: the middle estimate sits 1.8-fold (0.26 log units) below what was measured; the range from low to high includes it.
By their numbers in this assay, from the lowest: compounds 3, 2, 4 and 1 (each within the scatter of the next, the first and the last beyond it).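

In this assay, among the compounds shown here, the aromatic nitrogen that took a methyl with no step beyond the scatter proves sensitive to what is carried further out on the chain: carbamoyl in place of hydrogen on the saturated chain carbon gives a 2.3-fold higher number from compound 3 to compound 4 (0.36 log units; beyond the scatter) and this is the first single-point step to rise above the scatter. Counted from the unsubstituted nitrogen, carbamoylmethyl in place of hydrogen gives a 1.4-fold higher number from compound 2 to compound 4 (0.16 log units; within the scatter) and so the whole group leaves compound 4 level with compound 2, with the difference showing only against the methyl of compound 3. No evidence at hand accounts for this step.

A carboxylic acid or an amine in place of the carbamoyl, or a longer chain ahead of it, would tell whether the higher number follows the carbamoyl itself or any extension beyond methyl. The compounds shown also leave open whether carbamoylmethyl would produce a step of similar size on the core of compound 1.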